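Series notes: from compound 3 toward compound 4

The source may hold more compounds than are shown below. What is called first, only, known or untested is meant among the compounds shown, and "the series" means these compounds.

Measured so far in an assay (Rattus norvegicus) for inhibition of Fatty-acid amide hydrolase 1 (Homo sapiens); on this read-out lower numbers stand for stronger inhibition and higher numbers for weaker inhibition:
- compound 1 `O=C(CCCCCCc1ccccc1)c1ncc(-c2ccc(O)cc2)o1` gives 140 nM
- compound 2 `O=C(CCCCCCc1ccccc1)c1ncc(-c2ccncn2)o1` gives 2.3 nM
- compound 3 `CC(=O)c1cnc(C(=O)CCCCCCc2ccccc2)o1` gives 2 nM

Compound 3 carries the lowest number of the three, but its separation from compound 2, a 1.2-fold lower number from compound 2 to compound 3 (0.06 log units; within the scatter), lies within the scatter, so the two cannot be ordered. Only compound 1 stands clearly apart: a 70-fold lower number from compound 1 to compound 3 (1.85 log units; beyond the scatter) and a 61-fold lower number from compound 1 to compound 2 (1.78 log units; beyond the scatter) are both large and both come from exchanging the group on the aromatic carbon of the shared core.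

Compound 4 `O=C(CCCCCCc1ccccc1)c1ncc(C(=O)C(F)(F)F)o1` keeps the pyrimidinyl-free, acetyl-type arrangement of compound 3 and alters only the acetyl group itself: trifluoromethyl in place of methyl on a carbonyl carbon.

Among the compounds with values here, none of the measured steps bears on this change. Within the data shown here, every step so far moves a whole group on the aromatic carbon; nothing measured varies the substituent on the carbonyl carbon, and no pair of compounds differs there. The step to compound 4 is therefore unsupported by any precedent in this set, and the only defensible expectation is a step in this assay that stays close to compound 3.

Compound 4 is expected to give about 1.5 nM in this assay, with a range of 0.4 nM to 6 nM, which means an expected step of a 1.3-fold lower number from compound 3 to compound 4 (0.12 log units; within the scatter), not beyond the scatter.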

Compound 4, inhibition constant: 4 nM
Estimate against measurement, compound 4: 2.7-fold (0.43 log units) below, and the stated range covers the measured number.
By their numbers in this assay, from the lowest: compounds 3, 2 and 4 (each within the scatter of the next); then compound 1.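

In this assay the first variation on the carbonyl carbon itself, trifluoromethyl in place of methyl, gives a 2.0-fold higher number from compound 3 to compound 4 (0.30 log units; within the scatter), so on these numbers the two groups cannot be told apart at this place. The (trifluoromethyl)carbonyl group also cannot be ordered against pyrimidin-4-yl on the aromatic carbon (a 1.7-fold higher number from compound 2 to compound 4 (0.24 log units; within the scatter)), yet it keeps a large separation from 4-hydroxyphenyl (a 35-fold lower number from compound 1 to compound 4 (1.54 log units; beyond the scatter)), so three different groups now lie within the scatter of one another while only the 4-hydroxyphenyl compound stands apart. Nothing available explains why this exchange on the carbonyl carbon leaves the number within the scatter.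

Still open, on these data alone, is how far the carbonyl carbon tolerates change, since a single pair covers it: an ethyl or a longer chain in place of methyl, or the carbonyl carried as a carboxylic acid or an amide, could show whether the flat result holds. Also open, as far as these compounds go, is whether a carbonyl on the aromatic carbon is needed at all, which a nitrile or a plain methyl there would address.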